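The source may report more compounds than this note shows. Statements on the series, on what has been measured and on what is new or still open speak of the compounds shown alone.

Compound 2, `COc1ccc(C(=O)c2cc(OC)c(OC)c(OC)c2)cc1NC(=O)/C=C/c1cc(OC)c(OC)c(OC)c1`, is compared with compound 1, `COc1ccc(C(=O)c2cc(OC)c(OC)c(OC)c2)cc1N`, in a functional assay on PC-3 cells (Homo sapiens) for cytotoxicity, read by MTT assay, with a stated time of 72 h; on this read-out higher numbers stand for weaker inhibition and lower numbers for stronger inhibition. Of the two numbers in hand, compound 2 gives the higher one: in this assay compound 2 gives 3900 nM, while compound 1 gives 1100 nM. The gap between these two values lies beyond the usual scatter of repeated measurements, so compound 2 is the weaker of the two.

The step to compound 3, `COc1ccc(C(=O)c2cc(OC)c(OC)c(OC)c2)cc1NC(=O)/C=C/c1ccc(OC)c(OC)c1`, changes only the cinnamamide arm: hydrogen in place of methoxy on an aromatic carbon. Cut one bond further out, the trimethoxyphenyl of compound 2 becomes a dimethoxyphenyl in compound 3. For the measured compounds named here, no measured pair here shows what such a change does, so the expected step from compound 2 to compound 3 in this assay, a 1.3-fold higher number from compound 2 to compound 3 (0.11 log units; within the scatter), is small and is estimated to sit within or just beyond the scatter. Compound 3 is therefore expected to give about 5000 nM, within a range from 1500 nM to 15000 nM.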

Compound 3, half-maximal inhibitory concentration: 7500 nM
For compound 3 the middle estimate is 1.5-fold (0.18 log units) below the measured one, and the stated range covers the measured number.
By their numbers in this assay, from the lowest: compound 1; then compounds 2 and 3 (each within the scatter of the next).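

In this assay, hydrogen in place of methoxy on this aromatic carbon gives a 1.9-fold higher number from compound 2 to compound 3 (0.28 log units; within the scatter) and so leaves compound 2 and compound 3 indistinguishable. The 3,4,5-trimethoxyphenyl group and the 3,4-dimethoxyphenyl group therefore cannot be told apart on this read-out, so this one methoxy group shows no measurable contribution here, a point that the comparison of compound 1 with compound 2 could not address. For the compounds shown here, nothing at hand gives a reason for this result, and the single step offers no basis for a wider pattern.

On these data alone, what remains open is whether a different group on this carbon, such as a hydroxyl, an amine or a fluorine atom, would separate from hydrogen and methoxy. As far as these compounds go, it is also open whether losing either of the two remaining methoxy groups on this ring would matter in this assay as well.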